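Methoxy-to-hydrogen step carried over to a second core

The compounds below may be only part of what the source reports. "The series", "measured", "known", "first", "only" and "open" are said of these compounds alone.

Compound 1 `COc1cc(-c2cc(/C=C/C(=O)c3ccc(N)cc3)[nH]n2)cc(OC)c1OC` and compound 2 `COc1ccc(-c2cc(/C=C/C(=O)c3ccc(N)cc3)[nH]n2)cc1OC` share one core; compound 3 `COc1cc(C(=O)/C=C/c2cc(-c3cc(OC)c(OC)c(OC)c3)n[nH]2)cc(OC)c1OC` and compound 4 `COc1ccc(-c2cc(/C=C/C(=O)c3cc(OC)c(OC)c(OC)c3)[nH]n2)cc1OC` share another, and the difference between the two cores is not broken down here. In a functional assay on A549 cells (Homo sapiens) for cytotoxicity, read by sulforhodamine B assay, with a stated time of 48 h, tested at 1 uM (on this read-out higher numbers stand for a weaker effect at the one concentration tested and lower numbers for a stronger effect), compound 1 gives 80% and compound 2 gives 89%; the change hydrogen in place of methoxy on an aromatic carbon brings a number 9 percentage points higher from compound 1 to compound 2 (within the scatter). In this assay compound 3 gives 84%. Compound 4 differs from compound 3 by hydrogen in place of methoxy on an aromatic carbon, the same kind of change, at a place described in the same words. For the measured compounds named here, a step of about a number 5 percentage points higher from compound 3 to compound 4 (within the scatter) is expected, resting on a number 9 percentage points higher from compound 1 to compound 2 (within the scatter), which is the only measured instance of this change. Compound 4 is estimated to give 89% in this assay, between 76% and 100%.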

Compound 4, a percentage reported as activity, at one concentration (the size of the read-out at that concentration, not a potency): 82%
The estimate for compound 4 lay 7 percentage points above the measured number; the measured number falls inside the stated range.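

In this assay, hydrogen in place of methoxy on an aromatic carbon brings a number 2 percentage points lower from compound 3 to compound 4 (within the scatter). Set beside the step on the core of compound 1, the new step does not differ from it beyond the scatter: the same change on two cores in this assay, a number 9 percentage points higher (within the scatter) from compound 1 to compound 2 and a number 2 percentage points lower (within the scatter) from compound 3 to compound 4, 11 percentage points apart, within the scatter of two such steps

Within this read-out, the two cores therefore give no sign of responding differently to the change, but neither step is distinguishable from no change, so this is agreement between two small steps and does not show a shared effect of the change. Two instances at one concentration also cannot show that the step would hold on other cores.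

Going by these compounds, it remains open whether a different group at this place, such as hydroxy or chlorine, would move the number beyond the scatter. Also open, on these data alone, is how these compounds compare at other concentrations.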